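The source may report more compounds than this note shows. Statements on the series, on what has been measured and on what is new or still open speak of the compounds shown alone.

Measured compounds in a functional assay on BeWo cells (Homo sapiens) for inhibition, read by MTT assay, with a stated time of 72 h; on this read-out lower numbers stand for stronger inhibition and higher numbers for weaker inhibition:
Compound 1, `OCC(CO)(CO)Nc1nnc2nncn2n1`, gives 12400 nM.
Compound 2, `CCCCCC(=O)N1CCN(c2nnc3nncn3n2)CC1`, gives 2960 nM.
Compound 3, `CN(C)c1nnc2nncn2n1`, gives 610 nM.

All three share one core and differ only in the group attached to it. On these numbers compound 2 stands second highest of the three: compound 1 sits above it by a gap beyond the usual scatter, and compound 3 sits below it by a gap that is also beyond the scatter, so compound 2 is clearly in the middle.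

The unmeasured compound 4, `CC(C)(C)C(=O)N1CCN(c2nnc3nncn3n2)CC1`, differs from compound 2 in one place:
tert-butyl in place of pentyl on a carbonyl carbon
The group that leaves and the group that enters are both small carbon groups of nearly the same size, with no donors, acceptors or charge on either side. Within the data shown here, no measured pair shows this kind of exchange, so there is nothing to scale it by. The step is expected to be small, a 1.2-fold higher number from compound 2 to compound 4 (0.07 log units; within the scatter), plausibly within the scatter, with a slight lean towards a weaker number. Compound 4 is therefore estimated at 3500 nM, within a range from 1200 nM to 10000 nM.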

Compound 4, half-maximal inhibitory concentration: 2410 nM
Compound 4: the middle estimate sits 1.5-fold (0.16 log units) above what was measured; the range from low to high includes it.
By their numbers in this assay, from the lowest: compound 3; then compounds 4 and 2 (each within the scatter of the next); then compound 1.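

In this assay, putting tert-butyl in place of pentyl on the carbonyl carbon gives a 1.2-fold lower number from compound 2 to compound 4 (0.09 log units; within the scatter), so the two compounds cannot be told apart. This is the first pair shown that differs in one place, and it gives the first direct reading of this position: here, a group with one heavy atom fewer, all carbon in both cases, makes no difference beyond the scatter. No measurement of any property of these two groups comes with the numbers, so the result stands as a plain observation. One exchange between two small carbon groups says little about the position as a whole. As far as these compounds go, it remains open how a much longer chain, a phenyl ring, or a chain ending in an amine or a carboxylic acid would read on the same carbonyl carbon.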